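A 4-iodophenyl group on the shared core

The source may hold more compounds than are shown below. What is called first, only, known or untested is meant among the compounds shown, and "the series" means these compounds.

Measured in a functional assay on ECa-109 cells for inhibition, with ECa-109 cell line (Homo sapiens) as the target, read by sulforhodamine B assay; a higher number here means a weaker inhibitor, a lower number a stronger inhibitor:
compound 1 `O=C1C=C(Nc2cccc(F)c2)C(=O)c2c1nc1n2[C@H]2OC[C@@H](O)[C@H]2OC1` gives 7030 nM
compound 2 `CCOc1ccccc1NC1=CC(=O)c2nc3n(c2C1=O)[C@H]1OC[C@@H](O)[C@H]1OC3` gives 4630 nM

Compound 2, at 4630 nM, stands level with compound 1, since the two values lie within the scatter of each other. Compound 3 `O=C1C=C(Nc2ccc(I)cc2)C(=O)c2c1nc1n2[C@H]2OC[C@@H](O)[C@H]2OC1` keeps the shared core and differs from compound 2 in one group: 4-iodophenyl in place of 2-ethoxyphenyl on an amine nitrogen. For the measured compounds named here, only one measured step bears on this change. It also replaced the group on an amine nitrogen, and a 1.5-fold lower number from compound 1 to compound 2 (0.18 log units; within the scatter) stayed within the scatter. Neither measured compound carries iodine, so this single step is a thin guide. No step beyond the scatter is therefore expected in this assay, and no direction can be given. The expected change is a 1.1-fold higher number from compound 2 to compound 3 (0.03 log units; within the scatter). For compound 3 the estimated value is 5000 nM, with an expected range from 1800 nM to 14000 nM.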

Compound 3, half-maximal inhibitory concentration: 2300 nM
Compound 3: middle estimate off by 2.2-fold (0.34 log units), on the high side; the measured number falls inside the stated range.
By their numbers in this assay, from the lowest: compounds 3, 2 and 1 (each within the scatter of the next, the first and the last beyond it).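

In this assay, the 4-iodophenyl group gives the first difference on this amine nitrogen that lies beyond the scatter: a 3.1-fold lower number from compound 1 to compound 3 (0.49 log units; beyond the scatter), a modest step. Against the 2-ethoxyphenyl group, the same change gives a 2.0-fold lower number from compound 2 to compound 3 (0.30 log units; within the scatter), which remains within the scatter, so only the 3-fluorophenyl and 4-iodophenyl groups are separated here. No measurement available here accounts for this difference.

The 3-fluorophenyl and 4-iodophenyl groups differ in both their halogen and its printed place on the ring, so the compounds shown cannot separate those two changes. From the compounds shown here alone, how a 4-fluorophenyl or 4-bromophenyl group, or a saturated ring such as cyclohexyl, would read on this amine nitrogen remains open.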